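Replacing the methoxyphenyl amide on a thiazolidinedione core

The source may report more compounds than this note shows. Statements on the series, on what has been measured and on what is new or still open speak of the compounds shown alone.

Measured compounds:
Compound 1 `Cc1ccc(NC(=O)COc2ccc3cc(/C=C4/SC(=O)NC4=O)ccc3c2)cc1Cl`: > 50000 nM
Compound 2 `O=C(COc1ccc2cc(/C=C3/SC(=O)NC3=O)ccc2c1)Nc1c(F)cc(F)cc1Br`: > 50000 nM
Compound 3 `COc1cccc(NC(=O)COc2ccc3cc(/C=C4/SC(=O)NC4=O)ccc3c2)c1`: 7600 nM

In an assay on isolated protein for inhibition of histone deacetylase 8 (Homo sapiens), with a stated time of 1 h (a higher number here means a weaker inhibitor, a lower number a stronger inhibitor), compound 1 gives > 50000 nM, which is a limit of the assay and not a number. In this assay compound 2 likewise gives > 50000 nM, again a limit. Among the measured compounds shown here, compound 3 is the only one with a read number, 7600 nM, so it stands as the sole measured point; the two others sit at the limit of > 50000 nM in this assay, at which 2 of the 3 values shown sit.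

Compound 4 `Cc1cc(Br)ccc1NC(=O)COc1ccc2cc(/C=C3/SC(=O)NC3=O)ccc2c1` is not yet measured. It differs from compound 3 by 4-bromo-2-methylphenyl in place of 3-methoxyphenyl on an amide-type nitrogen. For the measured compounds named here, two measured steps bear on this change: an at least 6.5-fold lower number from compound 1 to compound 3 (0.81 log units; beyond the scatter) and an at least 6.5-fold lower number from compound 2 to compound 3 (0.81 log units; beyond the scatter). Both run toward the methoxy group and both gave a lower number beyond the scatter. Compound 4 moves away from that group, toward an aryl group carrying bromine and methyl as compounds 1 and 2 carry halogens and methyl, so a rise in the number is expected, a 5.3-fold higher number from compound 3 to compound 4 (0.72 log units; beyond the scatter), and quite possibly only a limit will be reported. Compound 4 is therefore estimated at 40000 nM, within 10000 nM to 150000 nM.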

Compound 4, half-maximal inhibitory concentration: 7400 nM
For compound 4 the middle estimate is 5.4-fold (0.73 log units) above the measured one; measured number below the stated range.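

In this assay, an oxygen on the aryl group proves not to be required at this position: there is a 1.0-fold lower number from compound 3 to compound 4 (0.01 log units; within the scatter), although 4-bromo-2-methylphenyl has no hydrogen-bond acceptor and 3-methoxyphenyl has one. A halogen on the aryl group is also no bar, and the three halogen-bearing groups do not behave alike: there is an at least 6.7-fold lower number from compound 2 to compound 4 (0.82 log units; beyond the scatter), and there is an at least 6.7-fold lower number from compound 1 to compound 4 (0.82 log units; beyond the scatter). Compound 1 and compound 2 each stand at a limit of the assay, not a number: the limit of > 50000 nM in this assay, at which 2 of the 4 values shown sit.

Compound 4 differs from compound 1 and from compound 2 in more than one ring substituent, so which substituent separates them remains unresolved. From the compounds shown here alone, it also remains open whether an amine or a carboxylic acid on this aryl ring would give a lower number than compound 3 and compound 4 do.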